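A few compounds are considered here, and "the series" means these few. Any claim that something is new, unique, unknown or untested is made for them only; others in the source may bear on it.

The measured compounds and their numbers in a functional assay on A549 cells (Homo sapiens) for antiproliferative activity, read by MTT assay, with a stated time of 72 h; a higher number here means a weaker inhibitor, a lower number a stronger inhibitor:
compound 1 `CNC(=O)c1cc(Oc2ccc(NC(=O)c3cc4cccnc4n(-c4ccccc4F)c3=O)cc2)ccn1`, 610 nM
compound 2 `CNC(=O)c1cc(Oc2ccc(NC(=O)c3cc4cccnc4n(-c4ccc(F)cc4)c3=O)cc2)ccn1`, 110 nM
compound 3 `CNC(=O)c1cc(Oc2ccc(NC(=O)c3cc4cccnc4n(-c4ccc(Cl)cc4)c3=O)cc2)ccn1`, 370 nM

Compound 3 stands second highest of the three in this assay. Its nearest neighbour by number lies within the scatter: a 1.6-fold lower number from compound 1 to compound 3 (0.22 log units; within the scatter); its furthest lies beyond it: a 3.4-fold higher number from compound 2 to compound 3 (0.53 log units; beyond the scatter).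

Compound 4 `CNC(=O)c1cc(Oc2ccc(NC(=O)c3cc4cccnc4n(-c4ccc(Br)cc4)c3=O)cc2)ccn1` differs from compound 3 by a single exchange: bromo in place of chloro on an aromatic carbon. Among the measured compounds shown here, of the measured steps, only one exchanges the halogen itself on the same aromatic carbon, namely a 3.4-fold higher number from compound 2 to compound 3 (0.53 log units; beyond the scatter), which went to a higher number by a modest amount. The other two steps, a 5.5-fold lower number from compound 1 to compound 2 (0.74 log units; beyond the scatter) and a 1.6-fold lower number from compound 1 to compound 3 (0.22 log units; within the scatter), move a halogen from one ring position to another and bear less directly on an exchange of chloro for bromo. For the measured compounds named here, because the one direct precedent a 3.4-fold higher number from compound 2 to compound 3 (0.53 log units; beyond the scatter) raised the number, a further small rise, or no change beyond the scatter, is expected for compound 4 in this assay, and the expected step of a 1.4-fold higher number from compound 3 to compound 4 (0.13 log units; within the scatter) is accordingly kept modest. Compound 4 is therefore estimated at 500 nM in this assay, with an expected range from 200 nM to 1300 nM.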

Compound 4, half-maximal inhibitory concentration: 1050 nM
Estimate against measurement, compound 4: 2.1-fold (0.32 log units) below; measured number inside the range.
By their numbers in this assay, from the lowest: compound 2; then compounds 3, 1 and 4 (each within the scatter of the next, the first and the last beyond it).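

In this assay the exchange of chloro for bromo gives a 2.8-fold higher number from compound 3 to compound 4 (0.45 log units; beyond the scatter) and so continues, in the same direction, the rise seen in a 3.4-fold higher number from compound 2 to compound 3 (0.53 log units; beyond the scatter), which means that among the three halogens at this place, para to a large group, fluoro gives the lowest number and bromo the highest. Taken end to end, the change from fluoro to bromo on this carbon amounts to a 9.5-fold higher number from compound 2 to compound 4 (0.98 log units; beyond the scatter) and is the largest step yet seen in the series. The gain of a 5.5-fold lower number from compound 1 to compound 2 (0.74 log units; beyond the scatter) therefore belongs to the 4-fluorophenyl group and does not carry over to the heavier halogen, since a 1.7-fold higher number from compound 1 to compound 4 (0.24 log units; within the scatter) leaves the 4-bromophenyl and 2-fluorophenyl compounds indistinguishable.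

The compounds shown carry only halogens on this ring, so it remains open whether the rise follows the halogen alone or would extend to a methyl, a methoxy, a nitrile or an amine at the same place, or how an unsubstituted phenyl would compare. Nothing available here accounts for the trend, which stands as an observation only.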